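A few compounds are considered here, and "the series" means these few. Any claim that something is new, unique, unknown or untested is made for them only; others in the source may bear on it.

Compound 1 `Cc1nnc(CN2CCCC2)n1-c1ccc(Cl)cc1C(=O)c1ccccc1` gives 89 mg/kg in a functional assay on the whole organism (strain CF-1) for inhibition, with Mus musculus as the target; a lower number here means that less compound is needed, a higher number that more compound is needed for the effect.
Compound 2 `CNCc1nnc(C)n1-c1ccc(Cl)cc1C(=O)c1ccccc1` gives 63 mg/kg in this assay.

Compound 1 stands at the upper end of these two numbers, yet the step from it to compound 2 is small: a 1.4-fold lower number from compound 1 to compound 2 (0.15 log units; within the scatter). Among the compounds with values here, that step replaces one amine on the saturated chain carbon with another, and it is the only measured step available.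

Compound 3 `Cc1nnc(CN2CCCC2)n1-c1ccc(Cl)cc1C(=O)c1ccccc1Cl` differs from compound 1 by chloro in place of hydrogen on an aromatic carbon, placed on an aromatic carbon of a six-membered aromatic ring of carbon only, ortho to a large group. Within the data shown here, no measured pair touches this ring, so the step from compound 1 to compound 2 bears on it only indirectly, showing that a single small change elsewhere in the shared core left this assay within the scatter. The expectation for compound 3 is therefore a modest step, most likely toward a lower number, of about a 1.8-fold lower number from compound 1 to compound 3 (0.25 log units; within the scatter), with wide uncertainty. Compound 3 is estimated at 50 mg/kg, between 15 mg/kg and 150 mg/kg.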

Compound 3, dose for half-maximal effect: > 100 mg/kg
Compound 3 gave a limit, no number; the forecaster's own chance of this, stated with the estimate: 5%; at least 2.0-fold (0.30 log units) between middle value and limit.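

For compound 3, this assay returns a limit, not a number: the limit of > 100 mg/kg in this assay, at which 1 of the 3 values shown sits. Chloro in place of hydrogen, on an aromatic carbon ortho to a large group, is the only change shown on this ring, and it reads as an at least 1.1-fold higher number from compound 1 to compound 3 (0.05 log units; that floor lies within the scatter). Only this floor is known, so the true size of the step stays undetermined, but the result gives no sign that 2-chlorophenyl in place of phenyl lowers the number needed for the effect.

The compounds shown leave open whether fluoro or methoxy in place of this chloro would give a measurable number in this assay. They also leave open how the methylamino group of compound 2 would read when combined with the 2-chlorophenyl group.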